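Aryl sulfonyl swap on the shared core

This account rests on a few compounds, and the source may have more. Where it says the series, first, only, none or still open, it means among the compounds named here.

Compound 1 `CN1CCN(c2ccc3[nH]nc(S(=O)(=O)c4ccccc4Cl)c3c2)CC1` gives 4 nM in an assay on HeLa cells for displacement of a labelled ligand from 5-hydroxytryptamine receptor 6 (Homo sapiens); on this read-out higher numbers stand for weaker inhibition and lower numbers for stronger inhibition.
Compound 2 `CC(C)Cn1nc(S(=O)(=O)c2cccc3ccccc23)c2cc(N3CCN(C)CC3)ccc21` gives 1.4 nM in this assay.
Compound 3 `Cc1ccc(S(=O)(=O)c2n[nH]c3cccc(N4CCNCC4)c23)cc1` gives 134 nM in this assay.

Compound 1 stands second highest of the three numbers in this assay: compound 2 lies below it by a step beyond the scatter, compound 3 far above it, also beyond the scatter. Compound 4 `COc1ccc(S(=O)(=O)c2n[nH]c3ccc(N4CCN(C)CC4)cc23)cc1` differs from compound 1 in one place: 4-methoxyphenyl in place of 2-chlorophenyl on a sulfonyl sulfur. Within the data shown here, no measured pair isolates this change; compounds 2 and 3 differ from compound 1 in the core and its substituents as well, so their numbers give no step for it. A small step toward a weaker number is expected, a 1.8-fold higher number from compound 1 to compound 4 (0.24 log units; within the scatter), close to the scatter rather than clearly beyond it. Compound 4 is estimated at 7 nM, range 1.5 nM to 30 nM.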

Compound 4, inhibition constant: 12 nM
For compound 4 the middle estimate is 1.7-fold (0.23 log units) below the measured one; low and high end bracket the measured number.
By their numbers in this assay, from the lowest: compound 2; then compound 1; then compound 4; then compound 3.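

Among these compounds, on the sulfonyl sulfur the aryl group is not interchangeable: in this assay, 4-methoxyphenyl in place of 2-chlorophenyl gives a 3.0-fold higher number from compound 1 to compound 4 (0.48 log units; beyond the scatter), the first single-place step. The change is modest, and the shared core keeps its number in the same assay after the swap of one aryl group for another. No measured property bears on the cause of this step. The swap alters both the substituent and its place on the ring, so the two effects remain unseparated. 4-Chlorophenyl, 2-methoxyphenyl or plain phenyl on the same sulfur would separate them.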